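Chain Lengthening Between Compound 3 and Compound 4

This account rests on a few compounds, and the source may have more. Where it says the series, first, only, none or still open, it means among the compounds named here.

Four compounds share one core, shown alone in compound 1 `O=C(O)c1ccc2c(c1)no[n+]2[O-]`, for which a functional assay on ES2 cells (Homo sapiens) for inhibition, read by MTT assay, with a stated time of 48 h (on this read-out lower numbers stand for stronger inhibition and higher numbers for weaker inhibition), gives "not determined" (no result reported). Compound 2 `O=C(CCCOC(=O)c1ccc2c(c1)no[n+]2[O-])NO` gives 27100 nM in this assay, and compound 3 `O=C(CCCCCOC(=O)c1ccc2c(c1)no[n+]2[O-])NO` gives 20600 nM in this assay. Compound 3 thus carries the lower of the two numbers shown, but its gap to compound 2 lies within the scatter. Compound 4 `O=C(CCCCCCCOC(=O)c1ccc2c(c1)no[n+]2[O-])NO` differs from compound 3 by 2-(hydroxycarbamoyl)ethyl in place of hydroxycarbamoyl on a saturated chain carbon, five bonds along the chain from an oxygen next to a carbonyl group. Among the compounds with values here, the only measured step that bears on this, a 1.3-fold lower number from compound 2 to compound 3 (0.12 log units; within the scatter), is the same kind of chain lengthening and stayed within the scatter. A step of similar size, with no direction beyond the scatter, is therefore expected, a 1.2-fold lower number from compound 3 to compound 4 (0.08 log units; within the scatter). Compound 4 is estimated at 17000 nM, ranging from 8000 nM to 40000 nM.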

Compound 4, half-maximal inhibitory concentration: 9230 nM
Compound 4: the middle estimate sits 1.8-fold (0.27 log units) above what was measured; the measured number falls inside the stated range.
By their numbers in this assay, from the lowest: compound 4; then compounds 3 and 2 (each within the scatter of the next).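

Here the chain change first moves the number beyond the scatter in this assay: going on to compound 4 gives a lower number (a 2.2-fold lower number from compound 3 to compound 4 (0.35 log units; beyond the scatter)), and the span across the chains shown is also beyond the scatter (a 2.9-fold lower number from compound 2 to compound 4 (0.47 log units; beyond the scatter)). Both steps are modest, but they show that chain length at this position can matter for this read-out. Nothing shown explains why the longest chain here gives the lowest number. Going by these compounds, whether a still longer chain would lower the number further remains open. So does what a carboxylic acid in place of the hydroxycarbamoyl end would give at this chain length.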